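Compound 3 and compound 4: one stereocentre drawn

A few compounds are considered here, and "the series" means these few. Any claim that something is new, unique, unknown or untested is made for them only; others in the source may bear on it.

The values in an ADME assay on MRC5 cells (Homo sapiens) for cytotoxicity, read by fluorescence, with a stated time of 72 h (a higher number here means a weaker inhibitor, a lower number a stronger inhibitor), are these
compound 1 `O=[N+]([O-])c1cn2c(n1)OC(COCc1ccc(OC(F)(F)F)cc1)C2` gives > 64000 nM as a limit of the assay
compound 2 `CC1(COCc2ccc(OC(F)(F)F)cc2)Cn2cc([N+](=O)[O-])nc2O1` gives 60000 nM as a number
compound 3 `O=[N+]([O-])c1cnc2n1CC(COc1ccc(OC(F)(F)F)cc1)O2` gives 31000 nM as a number

In this assay compound 2 at 60000 nM and compound 3 at 31000 nM lie within the scatter of each other. Compound 4 `O=[N+]([O-])c1cnc2n1C[C@@H](COc1ccc(OC(F)(F)F)cc1)O2` comes from compound 3 through the two compounds have the same atoms and bonds; at least one stereo element is drawn with a configuration in one of them and without one in the other: 1 of 1 stereo elements differ; a stereocentre at a saturated ring carbon is drawn without a configuration in compound 3 and S in compound 4 and through no other difference. Within the data shown here, the only measured step of an at least 1.0-fold lower number from compound 1 to compound 2 (0.02 log units; that floor lies within the scatter) is a methyl in place of hydrogen on a saturated ring carbon, so it does not bear directly on this change. Among the measured compounds shown here, no measured step concerns a configuration, so none beyond the scatter is expected. The expected step of a 1.0-fold lower number from compound 3 to compound 4 (0.01 log units; within the scatter) stays within the scatter. In this assay compound 4 is estimated at 30000 nM with an expected range from 16000 nM to 60000 nM for its measurement.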

Compound 4, half-maximal inhibitory concentration: > 64000 nM
Compound 4 gave a limit, no number; the forecaster's own chance of this, stated with the estimate: 15%; middle value at least 2.1-fold (0.32 log units) from the limit.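

In this assay, among these compounds, drawing this saturated ring carbon as S goes with an at least 2.0-fold higher number from compound 3 to compound 4 (0.31 log units; beyond the scatter), so a configuration at this position can shift the reading, which the earlier compounds did not show. That step is only a floor, as it rests on a limit of the assay: the limit of > 64000 nM in this assay, at which 2 of the 4 values shown sit. It also compares a defined centre with an undefined one: the fact that one of compounds 3 and 4 is drawn with a defined configuration and the other without, at the place where they differ

The compounds shown leave open how the R configuration reads at this carbon. They also leave open whether an amine in place of the trifluoromethoxy group would keep this reading.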